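Replacing a Methyl with a Benzoyl on a Shared Core

This account rests on a few compounds, and the source may have more. Where it says the series, first, only, none or still open, it means among the compounds named here.

Of the compounds shown here, three sharing one core have been measured in an ADME assay on a cell-free system (plasma, Homo sapiens) for metabolic stability, with Plasma (Rattus norvegicus) as the target, read by HPLC, at pH 7.4; a lower number here means that the compound disappears faster, a higher number that the compound lasts longer. Compound 1 `CC(=O)Oc1ccccc1C(=O)O[C@H]1CO[C@H]2[C@@H]1OC[C@H]2OC(=O)c1ccccc1O` gives 0.019 h, compound 2 `CC(=O)Oc1ccccc1C(=O)O[C@H]1CO[C@H]2[C@@H]1OC[C@H]2OC(=O)c1ccccc1C` gives 0.0138 h, and compound 3 `COc1ccccc1C(=O)O[C@@H]1CO[C@H]2[C@@H]1OC[C@@H]2OC(=O)c1ccccc1OC(C)=O` gives 0.0165 h. Compound 3 stands second highest of the three, yet every step among them lies within the scatter: a 1.4-fold lower number from compound 1 to compound 2 (0.14 log units; within the scatter), a 1.2-fold lower number from compound 1 to compound 3 (0.06 log units; within the scatter) and a 1.2-fold higher number from compound 2 to compound 3 (0.08 log units; within the scatter). Compound 4 `CC(=O)Oc1ccccc1C(=O)O[C@H]1CO[C@H]2[C@@H]1OC[C@H]2OC(=O)c1ccccc1OC(=O)c1ccccc1` differs from compound 3 by benzoyl in place of methyl on an oxygen on an aromatic ring. For the measured compounds named here, none of the measured steps covers such an exchange; the nearest is a 1.2-fold lower number from compound 1 to compound 3 (0.06 log units; within the scatter), which changed nothing beyond the scatter. In this assay compound 4 is therefore expected to show a 1.0-fold lower number from compound 3 to compound 4 (0.01 log units; within the scatter), with an estimated half-life of 0.016 h, ranging from 0.007 h to 0.035 h.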

Compound 4, half-life: 0.0722 h
For compound 4 the middle estimate is 4.5-fold (0.65 log units) below the measured one, and the stated range ends below it.
By their numbers in this assay, from the lowest: compounds 2, 3 and 1 (each within the scatter of the next); then compound 4.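

In this assay, the group on this oxygen on an aromatic ring can shift the half-life: benzoyl in place of methyl gives a 4.4-fold higher number from compound 3 to compound 4 (0.64 log units; beyond the scatter), whereas the earlier changes all stayed within the scatter. The two other steps agree, giving a 5.2-fold higher number from compound 2 to compound 4 (0.72 log units; beyond the scatter) and a 3.8-fold higher number from compound 1 to compound 4 (0.58 log units; beyond the scatter). Nothing available here accounts for this shift. From the compounds shown here alone, whether a plain hexanoyl chain on that oxygen would match benzoyl remains open, as does whether a benzoyl ring carrying an amine would keep the longer half-life.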